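This account rests on a few compounds, and the source may have more. Where it says the series, first, only, none or still open, it means among the compounds named here.

Measured so far:
compound 1, `CCc1cnc2c(C#N)c(N3CCC(c4ccccc4)CC3)ccn12`: 225%
compound 2, `N#Cc1c(N2CCC(c3ccccc3)CC2)ccn2c(CC(F)(F)F)cnc12`: 259%
compound 3, `N#Cc1c(N2CCC(c3ccccc3)CC2)ccn2c(CC(F)(F)F)nnc12`: 277%

All three values are maximal responses in a functional assay on CHO cells for positive allosteric modulation of metabotropic glutamate receptor 2 (Homo sapiens), read by GTPgammaS binding, with a stated time of 30 min; a higher number here means a larger maximal response, a lower number a smaller maximal response. Compound 3 stands highest of the three; compound 2 lies below it beyond the scatter, and compound 1 lies further below, also beyond the scatter. Going by the values given here, only one pair differs in a single place, and that step is large: a number 34 percentage points higher from compound 1 to compound 2 (beyond the scatter).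

Compound 4, `COCc1nnc2c(C#N)c(N3CCC(c4ccccc4)CC3)ccn12`, is not yet measured in this assay. It differs from compound 3 in one place: methoxy in place of trifluoromethyl on a saturated chain carbon bound to an aromatic carbon. The step from compound 1 to compound 2 bears on this, since there the trifluoromethyl entered and the response rose by a number 34 percentage points higher from compound 1 to compound 2 (beyond the scatter); compound 4 loses the trifluoromethyl again. Methoxy has not been seen anywhere in the series, so its own contribution is unknown. For compound 4 a drop beyond the scatter is therefore expected, of about the size of that earlier gain: a number 32 percentage points lower from compound 3 to compound 4 (beyond the scatter). The estimate for compound 4 in this assay is 245%, within 205% to 285%.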

Compound 4, largest response reached (Emax), in percent of the reference or control that the assay uses: 196%
For compound 4 the middle estimate is 49 percentage points above the measured one, and the stated range ends above it.
By their numbers in this assay, from the lowest: compound 4; then compound 1; then compound 2; then compound 3.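

In this assay the change from trifluoromethyl to methoxy on the saturated chain carbon bound to an aromatic carbon is a large step (a number 81 percentage points lower from compound 3 to compound 4 (beyond the scatter)). This shows that the group at this place moves the maximal response on the core of compound 3 as well, whereas the earlier step covered only trifluoromethyl in place of methyl on the core of compound 1. Going by these compounds alone, it is also the first reading for a group at this place that counts a hydrogen-bond acceptor, and nothing measured here accounts for the drop.

From the compounds shown here alone, it remains open whether the drop follows from the entry of methoxy or from the departure of trifluoromethyl. An ethyl, a hydroxymethyl or an aminomethyl group on the core of compound 3 would help separate the two.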